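Lengthening the Ester Chain from Compound 2 to Compound 3

A few compounds are considered here, and "the series" means these few. Any claim that something is new, unique, unknown or untested is made for them only; others in the source may bear on it.

The measurements come from a functional assay on HT-1080 cells (Homo sapiens), read by transwell migration, with a stated time of 24 h, tested at 1 uM; a higher number here means a weaker effect of the compound at the concentration tested, a lower number a stronger effect. Compound 1 `CC(=O)OCc1ccc2oc(=O)c(C(=O)Sc3ccccc3)cc2c1` gives 83.5% in this assay. Compound 2 `CCC(=O)OCc1ccc2oc(=O)c(C(=O)Oc3cccc(Br)c3)cc2c1` gives 40.2% in this assay, the lowest of the two numbers; the gap to compound 1 lies beyond the usual scatter, but the two compounds differ in more than one place, so no single change can be read from that gap.

Compound 3 `CCCCCC(=O)OCc1ccc2oc(=O)c(C(=O)Oc3cccc(Br)c3)cc2c1` has not yet been measured. It differs from compound 2 in one place: propyl in place of hydrogen on a saturated chain carbon, two bonds along the chain from a carbonyl carbon.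

Among the compounds with values here, no measured pair shows what such a chain lengthening does here, so the expectation rests on compound 2 alone. The step from compound 2 to compound 3 is expected to be small, a number 2.2 percentage points lower from compound 2 to compound 3 (within the scatter), most likely within the scatter and with no clear direction. Compound 3 is estimated at 38%, with a range from 18% to 62%.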

Compound 3, a percentage reported as activity, at one concentration (the size of the read-out at that concentration, not a potency): 59.3%
For compound 3 the middle estimate is 21.3 percentage points below the measured one; measured number inside the range.
By their numbers in this assay, from the lowest: compound 2; then compound 3; then compound 1.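

In this assay, within the data shown here, the pair of compound 2 and compound 3 gives the first comparison that changes only one place: propyl in place of hydrogen on a saturated chain carbon, two bonds along the chain from a carbonyl carbon, gives a number 19.1 percentage points higher from compound 2 to compound 3 (beyond the scatter). A higher number here means a weaker effect, so going from propanoyl to pentylcarbonyl costs part of the effect at the concentration tested, and this chain is not a place where length makes no difference. Nothing available explains why the longer chain does worse.

Two chain lengths cannot show whether the effect fades steadily with length or drops at one particular length. Also open, from the compounds shown here alone, is how a still longer chain, or a chain ending in an amine or a carboxylic acid, would read at this place.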